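A few compounds are considered here, and "the series" means these few. Any claim that something is new, unique, unknown or untested is made for them only; others in the source may bear on it.

Measured so far in an assay on CHO cells for displacement of a labelled ligand from adenosine receptor A1 (Homo sapiens), read by scintillation counting, with a stated time of 120 min, tested at 10 uM; a lower number here means less inhibition, a higher number more inhibition at the concentration tested (going by the name of the read-out):
compound 1 `Nc1scc(CN2CCN(c3ccc(F)cc3Cl)CC2)c1C(=O)c1ccc(Cl)cc1` gives 0%
compound 2 `COc1ccc(N2CCN(Cc3csc(N)c3C(=O)c3ccc(Cl)cc3)CC2)cc1` gives 0%
compound 3 `Nc1scc(CN2CCN(c3ccccc3C(F)(F)F)CC2)c1C(=O)c1ccc(Cl)cc1` gives 0%

Compound 3 stands level with compounds 1 and 2; all three share one core and differ only in the aryl group on an amine nitrogen in a ring, and none of them shows measurable inhibition. Compound 4 `Nc1scc(CN2CCN(c3cccnc3)CC2)c1C(=O)c1ccc(Cl)cc1` is the next member of this set, and the change from compound 3 is pyridin-3-yl in place of 2-(trifluoromethyl)phenyl on an amine nitrogen in a ring.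

Going by the values given here, three measured steps bear on this change, since each of them also swaps the aryl group at the same place: no change at the digits printed from compound 1 to compound 2 (within the scatter), no change at the digits printed from compound 1 to compound 3 (within the scatter) and no change at the digits printed from compound 2 to compound 3 (within the scatter). Whether the aryl group carries a methoxy, a chloro and a fluoro, or a trifluoromethyl, the read-out stays at the bottom of the scale. A pyridin-3-yl group at the same place is therefore expected to behave no differently, so the step of no change at the digits printed from compound 3 to compound 4 (within the scatter) is expected to fall within the scatter. For compound 4 the estimate is 0%, with a range from 0% to 12%.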

Compound 4, a percentage reported as inhibition, at one concentration (the size of the read-out at that concentration, not a potency): 0%
Compound 4: the middle estimate sits on the measured number at the digits printed; the measured number falls inside the stated range.
By their numbers in this assay, from the lowest: compounds 1, 2, 3 and 4 (each within the scatter of the next).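

In this assay the read-out shows no change at the digits printed from compound 3 to compound 4 (within the scatter) and no change at the digits printed from compound 2 to compound 4 (within the scatter) and no change at the digits printed from compound 1 to compound 4 (within the scatter) when pyridin-3-yl takes this place on the amine nitrogen. Compounds 1 to 3 all carry a six-membered aromatic ring of carbon only here, so compound 4 extends the flat result to a smaller aromatic ring with a hetero atom and a hydrogen-bond acceptor. No measurement here gives a reason for this flat read-out.

All four compounds sit at the bottom of the scale, so they cannot show whether the group at this place matters at all for this receptor. Going by these compounds, whether a benzyl group or a carboxylic acid here would lift the read-out from the bottom stays open, as does the effect of changes elsewhere on the shared core.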